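Swapping a Chloro for a Hydroxy on a Benzylidene Ketone

This account rests on a few compounds, and the source may have more. Where it says the series, first, only, none or still open, it means among the compounds named here.

Measured so far:
- Compound 1, `O=C1/C(=C/c2ccccc2)CCC/C1=C\c1ccc(Cl)cc1`: 27.6%
- Compound 2, `O=C(C1=C(O)/C(=C/c2ccc(O)c(O)c2)CCC1)c1ccccc1`: 55.9%

Both compounds were tested in an assay on isolated protein for inhibition of Alpha glucosidase (Homo sapiens), with stated times of 5 min and 15 min, tested at 50 uM; on this read-out higher numbers stand for more inhibition at the one concentration tested (going by the name of the read-out) and lower numbers for less inhibition. Compound 1 gives 27.6%, and this is the lower of the two numbers in hand. Compound 2, which carries phenolic hydroxy groups, gives 55.9%, a value that lies beyond the scatter above compound 1. The two compounds differ in several places at once. For the measured compounds named here, no single structural step between them can be read from these two numbers; they show only that the hydroxy-bearing compound sits higher.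

Compound 3, `O=C1/C(=C/c2ccccc2)CCC/C1=C\c1ccc(O)cc1`, has not yet been measured. It differs from compound 1 in one place: hydroxy in place of chloro on an aromatic carbon. Nothing measured here isolates the effect of that exchange, so any expectation rests on the two values above, and the higher value of compound 2 with its hydroxy groups gives some ground for expecting a rise.

The step from compound 1 to compound 3 is therefore expected to be a modest rise, a number 10.4 percentage points higher from compound 1 to compound 3 (beyond the scatter), possibly no larger than the scatter. Compound 3 is estimated at 38%, with a range from 20% to 58%.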

Compound 3, a percentage reported as inhibition, at one concentration (the size of the read-out at that concentration, not a potency): 53%
Estimate against measurement, compound 3: 15 percentage points below; the range from low to high includes it.
By their numbers in this assay, from the lowest: compound 1; then compounds 3 and 2 (each within the scatter of the next).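

Exchanging the 4-chlorophenyl for a 4-hydroxyphenyl, with the rest of the molecule unchanged, gives in this assay a number 25.4 percentage points higher from compound 1 to compound 3 (beyond the scatter). For the compounds shown here, this is the first comparison here in which a single change can be read: the read-out responds to what sits on this aromatic carbon, para to a large group, and the hydroxy, which brings a hydrogen-bond donor and a hydrogen-bond acceptor that the chloro does not, goes with more inhibition at the one concentration tested. Nothing available explains why this exchange raises the number.

With only chloro and hydroxy compared at this position, the compounds shown leave open whether the rise is particular to the hydroxy or would also appear with another group there, such as an amine, a methoxy or a carboxylic acid. They also leave open whether the same exchange on the other aromatic ring would give a similar step, and how a difference at one concentration would carry over to a true measure of potency.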